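Swapping 4-methoxyphenyl for 2-bromophenyl: what to expect

This account rests on a few compounds, and the source may have more. Where it says the series, first, only, none or still open, it means among the compounds named here.

In a functional assay on MCF7 cells (Homo sapiens) for antiproliferative activity, read by MTT assay, with a stated time of 48 h (on this read-out lower numbers stand for stronger inhibition and higher numbers for weaker inhibition), compound 1 `CC(=O)N1N=C(c2ccc3ccccc3c2)OC1c1ccccc1` gives 2.43 ug/mL as the lower number. Compound 2 `COc1ccc(C2OC(c3ccc4ccccc4c3)=NN2C(C)=O)cc1` stands as the higher of the two at 7.35 ug/mL on this scale. Compound 3 `CC(=O)N1N=C(c2ccc3ccccc3c2)OC1c1ccccc1Br` has 2-bromophenyl in place of 4-methoxyphenyl on a saturated ring carbon. Going by the values given here, one measured step bears on this change: a 3.0-fold higher number from compound 1 to compound 2 (0.48 log units; beyond the scatter) with methoxy in place of hydrogen on an aromatic carbon. Among the compounds with values here, the new group lacks methoxy as compound 1 at 2.43 ug/mL does, yet no measured compound carries bromine. In this assay only part of that modest step is therefore expected to reverse (a 1.8-fold lower number from compound 2 to compound 3 (0.26 log units; within the scatter)). Compound 3 is estimated at 4 ug/mL with a range from 1.3 ug/mL to 12 ug/mL as the expected span.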

Compound 3, half-maximal inhibitory concentration: 5.49 ug/mL
Estimate against measurement, compound 3: 1.4-fold (0.14 log units) below; the measured number falls inside the stated range.
By their numbers in this assay, from the lowest: compound 1; then compounds 3 and 2 (each within the scatter of the next).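

In this assay, 2-bromophenyl in place of 4-methoxyphenyl on the saturated ring carbon gives a 1.3-fold lower number from compound 2 to compound 3 (0.13 log units; within the scatter), so this exchange shows no real change in the read-out. Bromine, which no earlier compound carried, does separate compound 3 from the unsubstituted phenyl of compound 1, with a 2.3-fold higher number from compound 1 to compound 3 (0.35 log units; beyond the scatter), so both substituted compounds now sit on the weaker side of compound 1, whether the added group is methoxy or bromo and whichever ring place it holds. Nothing available explains why either added group weakens the result.

Methoxy and bromo are each seen at one ring place only, so the effect of the group cannot be separated from the effect of its place. On these data alone, whether an amine or a carboxylic acid on this phenyl ring would give a lower number than compound 1 remains open.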